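The source may report more compounds than this note shows. Statements on the series, on what has been measured and on what is new or still open speak of the compounds shown alone.

Of the compounds shown here, two of one shared core have been measured in an assay on CHO cells for binding affinity to adenosine receptor A3 (Homo sapiens), read by TR-FRET, with a stated time of 2 h; on this read-out higher numbers stand for weaker inhibition and lower numbers for stronger inhibition. Compound 1 `Cc1cccnc1CNC(=O)c1cnc(-c2ccco2)nc1N` carries only a hydrogen at the position of interest, and in this assay compound 1 gives 908 nM. Compound 2 `Cc1cccnc1CNC(=O)c1c(N)nc(-c2ccco2)nc1OC[C@H](C)O` carries a 2-hydroxypropoxy group there instead, and in this assay compound 2 gives 11 nM. The step of an 83-fold lower number from compound 1 to compound 2 (1.92 log units; beyond the scatter) is the only one that has been measured, and it shows that a group at this place makes a large difference. Compound 2 therefore stands lowest of the two numbers seen so far, far ahead of compound 1.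

Compound 3 `Cc1cccnc1CNC(=O)c1c(N)nc(-c2ccco2)nc1OCCF` keeps the oxygen-linked chain but changes its end: fluoromethyl in place of 1-hydroxyethyl on a saturated chain carbon bound to an oxygen on an aromatic ring. The hydroxyl that could donate and accept a hydrogen bond is gone, and the chain is one atom shorter. Within the data shown here, the only measured step bears on it indirectly: it shows that the chain as a whole matters, not which part of it. Compound 3 is expected to stay close to compound 2, with a modest weakening at most, estimated as a 2.7-fold higher number from compound 2 to compound 3 (0.44 log units; beyond the scatter). The expected value for compound 3 is 30 nM, within 8 nM to 120 nM.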

Compound 3, inhibition constant: 62 nM
For compound 3 the middle estimate is 2.1-fold (0.32 log units) below the measured one; measured number inside the range.
By their numbers in this assay, from the lowest: compound 2; then compound 3; then compound 1.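

In this assay, the change at the chain end gives a 5.6-fold higher number from compound 2 to compound 3 (0.75 log units; beyond the scatter), so at this position the make-up of the chain end matters, and not only the presence of a chain. The 2-fluoroethoxy group still keeps a clear part of the gain over a bare hydrogen, with a 15-fold lower number from compound 1 to compound 3 (1.17 log units; beyond the scatter), which shows that a large gain at this place does not depend on having a hydrogen-bond donor in the chain. No supporting evidence is available to explain why the fluoromethyl end gives a weaker result than the 1-hydroxyethyl end.

This swap removes the hydroxyl, the defined stereocentre and one heavy atom all at once, so the compounds shown cannot say which of these differences accounts for the step. Still open, on these data alone, are how a 2-hydroxyethoxy chain, which would keep the hydroxyl without the extra carbon, or the mirror-image form of the 2-hydroxypropoxy group would compare, and whether an amine at the chain end or a longer chain would give a lower or higher number.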